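Replacing iodo with methyl: notes on the series

The compounds below may be only part of what the source reports. "The series", "measured", "known", "first", "only" and "open" are said of these compounds alone.

Among the measured compounds shown here, in a functional assay on M21 cells (Homo sapiens) for inhibition, read by sulforhodamine B assay, with a stated time of 48 h (a lower number here means a stronger inhibitor of growth, a higher number a weaker inhibitor of growth), compound 3 `Ic1ccc(NC2=NCCO2)cc1` gives 2000 nM, the lowest number so far, though it is not separated from compound 2 `CC(C)(C)c1ccc(NC2=NCCO2)cc1` at 2400 nM. The step between them is a 1.2-fold lower number from compound 2 to compound 3 (0.08 log units; within the scatter). Compound 1 `c1cc(OC2CCCC2)ccc1NC1=NCCO1` lies well apart at 21100 nM.

The next change leads to compound 4 `Cc1ccc(NC2=NCCO2)cc1`: methyl in place of iodo on an aromatic carbon, para to a group of 6 heavy atoms.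

For the measured compounds named here, no measured step involves methyl, so the evidence is indirect. Two steps away from cyclopentyloxy are large and similar: an 8.8-fold lower number from compound 1 to compound 2 (0.94 log units; beyond the scatter) and an 11-fold lower number from compound 1 to compound 3 (1.02 log units; beyond the scatter). The exchange of tert-butyl for iodo, a 1.2-fold lower number from compound 2 to compound 3 (0.08 log units; within the scatter), shows that two quite different groups at this position can give matching values. On these data alone, that favours a limited change over a jump towards the value of compound 1, but methyl remains untested, so some loss cannot be excluded.

A slight rise in the number is expected, estimated as a 1.8-fold higher number from compound 3 to compound 4 (0.24 log units; within the scatter), and it may not clear the scatter. For compound 4 the expected value in this assay is 3500 nM, with an estimated range from 1400 nM to 10000 nM.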

Compound 4, concentration for 50% growth inhibition: 22000 nM
Beside the measured number, compound 4's estimate is 6.3-fold (0.80 log units) below it; measured number above the stated range.
By their numbers in this assay, from the lowest: compounds 3 and 2 (each within the scatter of the next); then compounds 1 and 4 (each within the scatter of the next).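

Working notes after compound 4: in this assay, the exchange of iodo for methyl, each counted as 1 heavy atom, gives an 11-fold higher number from compound 3 to compound 4 (1.04 log units; beyond the scatter), so the heavy-atom count of the group at this position does not by itself set the number. Methyl also separates from tert-butyl, with a 9.2-fold higher number from compound 2 to compound 4 (0.96 log units; beyond the scatter), yet cannot be told apart from cyclopentyloxy, with a 1.0-fold higher number from compound 1 to compound 4 (0.02 log units; within the scatter), so the four compounds now fall into two groups: iodo with tert-butyl at the lower numbers, and methyl with cyclopentyloxy at the higher numbers. The data offered here contain nothing that explains this division.

The compounds shown leave open whether ethyl, isopropyl, chloro or bromo at this position would join iodo and tert-butyl or join methyl, and so whether the rise seen on reaching methyl is graded or abrupt. Also open, on these data alone, is where an amine, a carboxylic acid or a shorter ether such as methoxy would fall, which would show whether the high number of cyclopentyloxy extends to other groups attached through oxygen or to other polar groups.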